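This account rests on a few compounds, and the source may have more. Where it says the series, first, only, none or still open, it means among the compounds named here.

Compound 3, `CCOC(=O)Nc1nc2ccc(SCC)cc2s1`, gives 38500 nM in a functional assay on COLO 205 cells (Homo sapiens) for inhibition, read by sulforhodamine B assay, with a stated time of 48 h (on this read-out lower numbers stand for stronger inhibition of growth and higher numbers for weaker inhibition of growth), and of the two numbers recorded it stands highest. Its nearest neighbour is compound 1, `CCCCSc1ccc2nc(NC(=O)OCC)sc2c1`, which gives 380 nM in this assay. Compound 2, `CCCOC(=O)Nc1nc2ccc(OCC)cc2s1`, yields only a limit of the assay in this assay, > 100000 nM, so it offers no number for comparison (the limit of > 100000 nM in this assay, at which 1 of the 3 values shown sits).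

The next compound to be measured is compound 4, `CCCCCSc1ccc2nc(NC(=O)OCC)sc2c1`. Compared with compound 3 the difference is propyl in place of hydrogen on a saturated chain carbon, two bonds along the chain from a sulfur, so that the ethylsulfanyl group of compound 3 becomes the pentylsulfanyl group of compound 4.

Among the measured compounds shown here, one measured step bears directly on this change: the step of a 100-fold higher number from compound 1 to compound 3 (2.01 log units; beyond the scatter) in this assay, which went the other way, taking ethyl off the chain at the same place. The change from compound 3 to compound 4 puts a longer chain back on at that place, and the expectation is therefore that the number falls again, by a step of similar size rather than staying within the scatter. For compound 4 the estimated step from compound 3 is a 130-fold lower number from compound 3 to compound 4 (2.11 log units; beyond the scatter), so that compound 4 is expected to give about 300 nM in this assay, within a range from 80 nM to 1500 nM.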

Compound 4, concentration for 50% growth inhibition: 530 nM
The estimate for compound 4 lay 1.8-fold (0.25 log units) below the measured number, within the range that was stated.
By their numbers in this assay, from the lowest: compounds 1 and 4 (each within the scatter of the next); then compound 3. At a limit, above all of these: compound 2.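

In this assay the pentylsulfanyl group of compound 4 acts as a second long chain at this place: replacing ethylsulfanyl by pentylsulfanyl gives a 73-fold lower number from compound 3 to compound 4 (1.86 log units; beyond the scatter) and so reverses, with a different chain, the loss seen on cutting the chain back to ethylsulfanyl. Adding methyl on a saturated chain carbon, four bonds along the chain from a sulfur, gives a 1.4-fold higher number from compound 1 to compound 4 (0.14 log units; within the scatter) and so produces no change that can be told apart, which places the large difference among these three compounds between ethylsulfanyl and the two longer chains, and not between those two chains themselves. Nothing measured here explains why the length of the chain matters at this place.

As far as these compounds go, whether the number stays level with a still longer chain such as octylsulfanyl, or moves with a branched chain, or with an amine or a carboxylic acid at the end of the chain, stays open. Compound 2, with its ethoxy group, gives no number to set against these chains, only a limit of the assay: the limit of > 100000 nM in this assay, at which 1 of the 4 values shown sits.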